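Trimming the benzylic aryl group of compound 2

The compounds below may be only part of what the source reports. "The series", "measured", "known", "first", "only" and "open" are said of these compounds alone.

Three sulfonamide-linked benzylamines have been measured in a functional assay on ASPC1 cells (Homo sapiens) for inhibition, read by MTT assay, with a stated time of 72 h; a lower number here means a stronger inhibitor of growth, a higher number a weaker inhibitor of growth. Compound 2 `O=S(=O)(NCCCNCc1ccc(Cl)c(C(F)(F)F)c1)c1cc(C(F)(F)F)cc(C(F)(F)F)c1` gives 9600 nM, the highest number among the three and therefore the weakest growth inhibitor of the set. Compound 1 `O=S(=O)(NCCNCc1ccc(-c2ccccc2)cc1)c1cc(C(F)(F)F)cc(C(F)(F)F)c1` gives 2800 nM in this assay, and compound 3 `O=S(=O)(NCCCNCc1ccc(C(F)(F)F)cc1)c1cc(C(F)(F)F)cc(C(F)(F)F)c1` gives 2000 nM. Among the compounds with values here, only one single-point step exists among the measured compounds, a 4.8-fold lower number from compound 2 to compound 3 (0.68 log units; beyond the scatter), in which the benzylic aryl group loses its chlorine and keeps a single trifluoromethyl group; the number falls by a modest amount.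

Compound 4 `O=S(=O)(NCCCNCc1cccc(Cl)c1)c1cc(C(F)(F)F)cc(C(F)(F)F)c1` is the next compound in line, and it differs from compound 2 in one place: 3-chlorophenyl in place of 4-chloro-3-(trifluoromethyl)phenyl on a saturated chain carbon bound to an amine nitrogen. This change again reduces the substitution on the benzylic aryl group of compound 2, so the step from compound 2 to compound 3 is the closest guide. On that basis a downward step of modest size is expected in this assay, though the direction and size rest on a single precedent. Compound 4 is therefore expected to give about 3500 nM in this assay, with a likely range from 1200 nM to 10000 nM. That estimate corresponds to an expected step of a 2.7-fold lower number from compound 2 to compound 4 (0.44 log units; beyond the scatter).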

Compound 4, concentration for 50% growth inhibition: 5900 nM
Compound 4: the middle estimate sits 1.7-fold (0.23 log units) below what was measured; the range from low to high includes it.
By their numbers in this assay, from the lowest: compounds 3 and 1 (each within the scatter of the next); then compounds 4 and 2 (each within the scatter of the next).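

In this assay, 3-chlorophenyl in place of 4-chloro-3-(trifluoromethyl)phenyl on a saturated chain carbon bound to an amine nitrogen gives a 1.6-fold lower number from compound 2 to compound 4 (0.21 log units; within the scatter) and so leaves compound 4 indistinguishable from compound 2, even though the group shrinks from 11 heavy atoms to 7. Set against compound 3, the same position gives a 3.0-fold higher number from compound 3 to compound 4 (0.47 log units; beyond the scatter) for 3-chlorophenyl in place of 4-(trifluoromethyl)phenyl, which shows that reducing this aryl group does not by itself bring the number down and that the choice of group matters here. No measurement at hand accounts for either step.

The compounds shown leave open whether the separation of compound 3 from compound 4 follows the change of chlorine to trifluoromethyl or the different placement of the group on the ring, since the two differ in both at once. A 4-chlorophenyl or a 3-(trifluoromethyl)phenyl group at this position would pull those two apart, and an unsubstituted phenyl group would show what either substituent contributes in this assay on this shared core.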